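The source may hold more compounds than are shown below. What is called first, only, known or untested is meant among the compounds shown, and "the series" means these compounds.

Compounds measured so far: compound 1 `S=C(Nc1ccccc1)N1N=C(c2ccc(Br)cc2)CC1c1ccc2c(c1)OCCO2` with 870 nM; compound 2 `CSc1ccc(C2=NN(C(=S)Nc3ccccc3)C(c3ccc4c(c3)OCCO4)C2)cc1` with 197000 nM; compound 3 `COc1cccc(C2=NN(C(=S)Nc3ccccc3)C(c3ccc4c(c3)OCCO4)C2)c1` with 1380 nM.

All three share one core and differ only in the aromatic group attached to the carbon that carries a double bond to nitrogen. In a functional assay on WM 266-4 cells (Homo sapiens) for antiproliferative activity, read by MTT assay, with a stated time of 48 h (a lower number here means a stronger inhibitor of growth, a higher number a weaker inhibitor of growth), compound 3 stands second highest of the three numbers. Its nearest neighbour is compound 1, and the step of a 1.6-fold higher number from compound 1 to compound 3 (0.20 log units; within the scatter) stays within the scatter, so no order between these two can be read. Its furthest neighbour is compound 2, and the step of a 140-fold lower number from compound 2 to compound 3 (2.15 log units; beyond the scatter) is large. The step of a 230-fold higher number from compound 1 to compound 2 (2.35 log units; beyond the scatter) shows the same thing from the other side: a change of the substituent on this aromatic ring can move this assay enormously, or hardly at all.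

Compound 4 `Cc1ccc(C2=NN(C(=S)Nc3ccccc3)C(c3ccc4c(c3)OCCO4)C2)cc1C` is not yet measured. It differs from compound 3 by 3,4-dimethylphenyl in place of 3-methoxyphenyl on a carbon with a double bond to nitrogen. Two of the three known steps at this ring were within or close to the scatter, one was very large, so the expected step of a 1.8-fold higher number from compound 3 to compound 4 (0.26 log units; within the scatter) is uncertain. For compound 4 the estimate is 2500 nM, between 500 nM and 40000 nM.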

Compound 4, concentration for 50% growth inhibition: 70500 nM
Compound 4: the middle estimate sits 28-fold (1.45 log units) below what was measured; measured number outside the range, above it.
By their numbers in this assay, from the lowest: compounds 1 and 3 (each within the scatter of the next); then compound 4; then compound 2.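

In this assay, for the compounds shown here, compound 2 no longer stands alone as the one very weak compound: a 51-fold higher number from compound 3 to compound 4 (1.71 log units; beyond the scatter) and an 81-fold higher number from compound 1 to compound 4 (1.91 log units; beyond the scatter) place compound 4 far from the two lowest numbers, while a 2.8-fold lower number from compound 2 to compound 4 (0.45 log units; beyond the scatter) leaves it only a modest distance from compound 2. The large step from 3-methoxyphenyl to 3,4-dimethylphenyl also shows that a change at this position can cost most of the growth inhibition even when the heavy-atom count stays the same. Nothing available explains why these four aromatic groups fall so far apart.

A 3-methylphenyl or a 4-methoxyphenyl group would help show which part of the change from compound 3 to compound 4 carries the step. Where a phenyl ring bearing an amine or a carboxylic acid would fall also remains open.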